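The compounds below may be only part of what the source reports. "The series", "measured", "known", "first", "only" and "open" are said of these compounds alone.

Measured so far in a physicochemical assay for lipophilicity; on this read-out lower numbers stand for lower lipophilicity and higher numbers for higher lipophilicity:
compound 1 `CCOC(=O)C1C(=O)C=C(Nc2ccccc2N2CCN(C)CC2)CC1c1ccccc1`: 4.35
compound 2 `CCOC(=O)C1C(=O)C=C(Nc2ccccc2N2CCN(C)CC2)CC1C`: 3.02
compound 3 `CCN1CCN(c2ccc(NC3=CC(=O)C(C(=O)OC)C(c4ccccc4)C3)cc2)CC1`: 4.39

Compound 1 and compound 2 share a core and differ by methyl in place of phenyl on a saturated ring carbon; the step is a number 1.33 log units lower from compound 1 to compound 2 (beyond the scatter). Compound 3 has the same atoms as compound 1 joined differently; the difference between the two cores is not broken down here, and the values of compound 3 and compound 1 lie within the scatter of each other.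

Compound 4 `CCN1CCN(c2ccc(NC3=CC(=O)C(C(=O)OC)C(C)C3)cc2)CC1` has not been measured. It differs from compound 3 by methyl in place of phenyl on a saturated ring carbon. This is the same kind of change as that from compound 1 to compound 2, the place differing only in that the neighbouring ring atom bears a methoxycarbonyl group in compound 3 and an ethoxycarbonyl group in compound 1.

Among the compounds with values here, the step from compound 3 to compound 4 in this assay is expected to be a number 1.33 log units lower from compound 3 to compound 4 (beyond the scatter), resting on a number 1.33 log units lower from compound 1 to compound 2 (beyond the scatter) as the one prior instance of this change. Compound 4 is accordingly estimated at 3.06, between 2.7 and 3.45.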

Compound 4, partition coefficient: 3.07
The estimate for compound 4 lay 0.01 log units below the measured number; the measured number falls inside the stated range.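

In this assay, methyl in place of phenyl on a saturated ring carbon gives a number 1.32 log units lower from compound 3 to compound 4 (beyond the scatter) and, on the other core, a number 1.33 log units lower from compound 1 to compound 2 (beyond the scatter) with nearly the same size, so this change carries across these two cores. This rests on two pairs only and does not show that the step would hold on a core beyond these. Nothing given here accounts for the size of the step.

The compounds shown leave open how an amine, a carboxylic acid or a longer chain on this saturated ring carbon would read in this assay on either core. They also leave open whether such groups would give steps that match between the two cores.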